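Isopropyl in Place of Methyl on the Amino Acid Chain

The source may report more compounds than this note shows. Statements on the series, on what has been measured and on what is new or still open speak of the compounds shown alone.

Compound 1, `NC(=O)C[C@H](NC(=O)CN(c1ncnc2c1ncn2C1CCCCO1)C1CC1)C(=O)OCc1ccccc1`: 29.2%
Compound 2, `C[C@H](NC(=O)CN(c1ncnc2c1ncn2C1CCCCO1)C1CC1)C(=O)OCc1ccccc1`: 25.3%

Of the compounds shown here, two have been measured in a functional assay on the whole organism (Tail, strain ICR) with Mus musculus as the target, in the tail flick test, with a stated time of 120 min, at a dose of 25 umol/kg by the oral route; on this read-out lower numbers stand for a weaker effect and higher numbers for a stronger effect at the one dose given. Compound 1 gives 29.2%, and compound 2 gives 25.3%. Going by the values given here, compound 2 holds the lowest of the two numbers, but the only step so far, a number 3.9 percentage points lower from compound 1 to compound 2 (within the scatter), lies within the scatter, so the two values cannot be ordered against each other.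

Compound 3, `CC(C)[C@H](NC(=O)CN(c1ncnc2c1ncn2C1CCCCO1)C1CC1)C(=O)OCc1ccccc1`, is not yet measured. It differs from compound 2 by isopropyl in place of methyl on a saturated chain carbon bound to an amide-type nitrogen and a carbonyl carbon. Among the compounds with values here, the one measured step bears on it only loosely: it also changed the substituent on the amino acid portion of the shared core, and it produced no movement beyond the scatter. Within the data shown here, nothing among the measured compounds shows that a larger alkyl group at this carbon would move the read-out. Compound 3 is therefore expected to show a step of a number 1.7 percentage points higher from compound 2 to compound 3 (within the scatter), that is, no change beyond the scatter, in this assay. Compound 3 is estimated at 27%, with a range from 12% to 42%.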

Compound 3, a percentage reported as activity, at one dose (the size of the read-out at that dose, not a potency): 25.8%
For compound 3 the middle estimate is 1.2 percentage points above the measured one, within the range that was stated.
By their numbers in this assay, from the lowest: compounds 2, 3 and 1 (each within the scatter of the next).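

In this assay, isopropyl in place of methyl on the saturated chain carbon bound to an amide-type nitrogen and a carbonyl carbon gives a number 0.5 percentage points higher from compound 2 to compound 3 (within the scatter), so going from 1 heavy atom to 3 heavy atoms in this alkyl group yields no difference that can be read. The step of a number 3.4 percentage points lower from compound 1 to compound 3 (within the scatter) likewise leaves isopropyl and carbamoylmethyl at this carbon indistinguishable, which means that methyl, isopropyl and carbamoylmethyl, the three groups shown here, all give values within the scatter of one another at the one dose tested. No supporting evidence is available that could explain this result.

The three compounds leave open whether a group of another kind at this carbon, such as an amine, a carboxylic acid or a phenyl group, would stand apart from these values in this assay. They also leave open whether a longer chain there would do so, and, since each value is a single-dose read-out, how the compounds compare in potency.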